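The source may hold more compounds than are shown below. What is called first, only, known or untested is meant among the compounds shown, and "the series" means these compounds.

Compound 1 `COc1cc(OC)c2sc(-c3ccc(N/C=C\C(=O)c4cc(OC)c(OC)c(OC)c4)cc3)nc2c1` is one of three analogues measured in a functional assay on HeLa cells (Homo sapiens) for antiproliferative activity, read by sulforhodamine B assay, with a stated time of 48 h; on this read-out higher numbers stand for weaker inhibition and lower numbers for stronger inhibition. In this assay compound 1 gives 17800 nM, the highest of the three numbers. Its nearest neighbour is compound 2 `COc1cc(OC)c2sc(-c3ccc(N/C=C\C(=O)c4cc(OC)c(OC)c(OC)c4Br)cc3)nc2c1`, which in this assay gives 10300 nM; the step of a 1.7-fold lower number from compound 1 to compound 2 (0.24 log units; within the scatter) introduces bromo in place of hydrogen on an aromatic carbon and stays within the scatter. The furthest is compound 3 `COc1ccc(C(=O)/C=C\Nc2ccc(-c3nc4cc(OC)c(OC)c(OC)c4s3)cc2C)cc1F`, which in this assay gives 1200 nM; it differs from compound 1 in several places at once, so its two values are reported without a single-change step.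

Compound 4 `COc1cc(OC)c2sc(-c3ccc(N/C=C\C(=O)c4ccc(OC)c([N+](=O)[O-])c4)cc3)nc2c1` is not yet measured. It differs from compound 1 by 4-methoxy-3-nitrophenyl in place of 3,4,5-trimethoxyphenyl on a carbonyl carbon. Among the compounds with values here, no measured step covers this exchange: the one step at hand, from compound 1 to compound 2, touches a different place and is within the scatter. The expectation for compound 4 therefore rests mainly on compound 1 itself, with wide uncertainty. Compound 4 is estimated at 15000 nM, with a range from 4000 nM to 60000 nM, which corresponds to an expected step of a 1.2-fold lower number from compound 1 to compound 4 (0.07 log units; within the scatter).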

Compound 4, half-maximal inhibitory concentration: 12900 nM
Beside the measured number, compound 4's estimate is 1.2-fold (0.07 log units) above it; the range from low to high includes it.
By their numbers in this assay, from the lowest: compound 3; then compounds 2, 4 and 1 (each within the scatter of the next).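

On the carbonyl carbon, 4-methoxy-3-nitrophenyl in place of 3,4,5-trimethoxyphenyl gives, in this assay, a 1.4-fold lower number from compound 1 to compound 4 (0.14 log units; within the scatter). Within the data shown here, this is the first reading at this place, and it shows that the whole aryl group can be exchanged without the number leaving the scatter: the trimethoxy pattern is not needed to hold the level of compound 1, and the nitro group brings no step beyond the scatter. Nothing at hand explains this result.

The exchange alters the ring in more than one way at once, so the share of the nitro group and the share of the lost methoxy groups remain unseparated. From the compounds shown here alone, whether an amine or a carboxylic acid in place of the nitro group would move the number beyond the scatter also remains open.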